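Removing the methoxy group from compound 2: expected potency

The source may hold more compounds than are shown below. What is called first, only, known or untested is meant among the compounds shown, and "the series" means these compounds.

Three amides on the shared core have numbers in a functional assay on MCF7 cells (Homo sapiens) for antiproliferative activity, read by MTT assay, with a stated time of 48 h; a higher number here means a weaker inhibitor, a lower number a stronger inhibitor. Compound 1 `CN(C)CCNc1cc2c(cn1)cc(NC(=O)c1ccc(N)cc1)c(=O)n2C` gives 55800 nM, compound 2 `COc1cccc(C(=O)Nc2cc3cnc(NCCN(C)C)cc3n(C)c2=O)c1` gives 43300 nM, and compound 3 `CN(C)CCNc1cc2c(cn1)cc(NC(=O)c1ccc(Cl)cc1)c(=O)n2C` gives 3090 nM. Compound 2 stands second highest of the three; the smaller gap is a 1.3-fold lower number from compound 1 to compound 2 (0.11 log units; within the scatter), while the drop to compound 3 is a 14-fold lower number from compound 2 to compound 3 (1.15 log units; beyond the scatter), and an 18-fold lower number from compound 1 to compound 3 (1.26 log units; beyond the scatter) is of the same order.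

Compound 4 `CN(C)CCNc1cc2c(cn1)cc(NC(=O)c1ccccc1)c(=O)n2C` is the parent phenyl amide, not yet measured. The change from compound 2 is hydrogen in place of methoxy on an aromatic carbon. For the measured compounds named here, no measured step removes a substituent without putting another in its place, so none bears on it directly. The step from compound 2 to compound 3 is the nearest, since the methoxy leaves there too, but a chloro enters at the same time; the step from compound 1 to compound 2 shows that two different substituents on that ring can give numbers within the scatter of each other. A modest shift toward compound 3 is therefore expected, not a large one. Compound 4 is estimated at 15000 nM in this assay, with a range of 5000 nM to 45000 nM. The expected step is a 2.9-fold lower number from compound 2 to compound 4 (0.46 log units; beyond the scatter).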

Compound 4, half-maximal inhibitory concentration: 35100 nM
Compound 4: the middle estimate sits 2.3-fold (0.37 log units) below what was measured, and the stated range covers the measured number.
By their numbers in this assay, from the lowest: compound 3; then compounds 4, 2 and 1 (each within the scatter of the next).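

In this assay the unsubstituted phenyl amide gives the series a reference point, and taking off the methoxy yields a 1.2-fold lower number from compound 2 to compound 4 (0.09 log units; within the scatter) so that the 3-methoxyphenyl and phenyl amides cannot be told apart. Against the same reference, hydrogen in place of amino yields a 1.6-fold lower number from compound 1 to compound 4 (0.20 log units; within the scatter) while hydrogen in place of chloro yields an 11-fold higher number from compound 3 to compound 4 (1.06 log units; beyond the scatter) and so, among these four compounds, chloro is the only substituent whose presence separates a compound from the phenyl amide beyond the scatter. Nothing measured here explains why the chloro compound stands apart from the other three.

On these data alone, whether this separation belongs to chloro alone remains open, since fluoro, bromo, methyl and trifluoromethyl groups on the same ring carbon would show whether other small substituents give a similar step. The position is also unresolved, as a chloro meta to a large group, on the carbon that carries the methoxy in compound 2, would show whether the step from compound 4 to compound 3 depends on where the chloro sits.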